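Trifluoromethyl for chloro on a short-lived compound

This account rests on a few compounds, and the source may have more. Where it says the series, first, only, none or still open, it means among the compounds named here.

In an ADME assay on the whole organism (strain Balb) for metabolic stability, with Mus musculus as the target, at a dose of 10 mg/kg by the intravenous route (a lower number here means that the compound disappears faster, a higher number that the compound lasts longer), compound 1 (`NC(=O)c1cc(-c2ccnc(N)n2)[nH]c1-c1cc(C(F)(F)F)ccc1Cl`) gives 1.1 h, while compound 2 (`CCc1ccc(Cl)cc1-c1[nH]c(-c2ccnc(N)n2)cc1C(N)=O`) gives 0.2 h, the lower of the two numbers and clearly beyond the usual scatter. Compound 3 (`CCc1ccc(C(F)(F)F)cc1-c1[nH]c(-c2ccnc(N)n2)cc1C(N)=O`) has trifluoromethyl in place of chloro on an aromatic carbon, para to an ethyl group (trifluoromethyl in place of chloro on an aromatic carbon). Among the measured compounds shown here, no measured pair shows this change alone, so the data offer little guidance on its size. The expected step of a 1.5-fold higher number from compound 2 to compound 3 (0.18 log units; within the scatter) is slightly upward and stays within the scatter. Compound 3 is estimated at 0.3 h, with an expected range of 0.12 h to 0.8 h.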

Compound 3, half-life: 1 h
The estimate for compound 3 lay 3.3-fold (0.52 log units) below the measured number; the whole stated range lies below it.
By their numbers in this assay, from the lowest: compound 2; then compounds 3 and 1 (each within the scatter of the next).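

Where the ring carries an ethyl group, trifluoromethyl in place of chloro on an aromatic carbon gives a clear gain in this assay: a 5.0-fold higher number from compound 2 to compound 3 (0.70 log units; beyond the scatter). With trifluoromethyl kept, ethyl in place of chloro on an aromatic carbon gives a 1.1-fold lower number from compound 1 to compound 3 (0.04 log units; within the scatter), so this swap does not separate the two compounds. Among these compounds, the short half-life appears only in compound 2, which pairs ethyl with chloro. Nothing measured here explains the gain. As far as these compounds go, whether an amine or a longer chain at the former chloro position would last as long remains open.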